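Chloro Substitution and Tolerated Concentration in a Triazole Series

The compounds below may be only part of what the source reports. "The series", "measured", "known", "first", "only" and "open" are said of these compounds alone.

Compound 1 `CC[C@H](CCn1cncn1)c1ccccc1` is the reference point of this small set. In an ADME assay on HEp-2 cells (Homo sapiens) for cytotoxicity, read by MTT assay, with a stated time of 3 days (a higher number here means that more compound is tolerated, a lower number that less compound is tolerated), compound 1 gives 97.7 ug/mL. Compound 2 `CC[C@H](CCn1cncn1)c1ccc(Cl)cc1` carries chloro in place of hydrogen on an aromatic carbon, and in this assay compound 2 gives 50.6 ug/mL, the step being a 1.9-fold lower number from compound 1 to compound 2 (0.29 log units; within the scatter). Compound 3 `c1ccc(C[C@H](CCn2cncn2)c2ccccc2)cc1` differs from compound 1 in its core by phenyl in place of methyl on a saturated chain carbon, two bonds along the chain from an aromatic carbon; in this assay compound 3 gives 60.9 ug/mL, and the step is a 1.6-fold lower number from compound 1 to compound 3 (0.21 log units; within the scatter). All three numbers lie within the scatter of one another, so no order among them can be claimed.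

Compound 4 `Clc1ccc([C@@H](CCn2cncn2)Cc2ccccc2)cc1` has not yet been measured in this assay. It differs from compound 3 by chloro in place of hydrogen on an aromatic carbon, which is the same change, at the same place, as that from compound 1 to compound 2; it occurs twice among these compounds. Going by the values given here, the step from compound 3 to compound 4 is expected to be about the size of the earlier one, namely a 1.7-fold lower number from compound 3 to compound 4 (0.24 log units; within the scatter), resting only on the single measured instance a 1.9-fold lower number from compound 1 to compound 2 (0.29 log units; within the scatter). Compound 4 is therefore estimated at 35 ug/mL, between 18 ug/mL and 70 ug/mL.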

Compound 4, half-maximal cytotoxic concentration: 25.9 ug/mL
Compound 4: middle estimate off by 1.4-fold (0.13 log units), on the high side, within the range that was stated.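

In this assay, going by these compounds alone, chloro in place of hydrogen gives a 2.4-fold lower number from compound 3 to compound 4 (0.37 log units; beyond the scatter), and the gap to its earlier instance cannot be told from scatter: the same change on two cores in this assay, a 1.9-fold lower number (0.29 log units; within the scatter) from compound 1 to compound 2 and a 2.4-fold lower number (0.37 log units; beyond the scatter) from compound 3 to compound 4, 1.2-fold (0.09 log units) apart, within the scatter of two such steps The phenyl change, read on the chloro-bearing core, gives a 2.0-fold lower number from compound 2 to compound 4 (0.29 log units; within the scatter), and it too agrees with its earlier instance: the same change on two cores in this assay, a 1.6-fold lower number (0.21 log units; within the scatter) from compound 1 to compound 3 and a 2.0-fold lower number (0.29 log units; within the scatter) from compound 2 to compound 4, 1.2-fold (0.09 log units) apart, within the scatter of two such steps On these two cores, then, each change carries over with a step of similar size, so the two changes together account for the values of these four compounds; but this rests on only two instances of each change, and it shows neither why the steps agree nor that they would hold on any other core.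

The compounds shown leave open how a bromo, methoxy or nitrile group would read in place of the chloro. They also leave open how a longer chain would read in place of the methyl of compound 1.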